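The source may report more compounds than this note shows. Statements on the series, on what has been measured and on what is new or still open speak of the compounds shown alone.

Measured so far in a functional assay on OCI-Ly3 cells (Homo sapiens) for antiproliferative activity; a higher number here means that more compound is needed for the effect, a lower number that less compound is needed:

compound 1 `Cc1c(NC(=O)Nc2cnc(-n3nccn3)c(Cl)c2)cnc2ccccc12` gives 7170 nM
compound 2 `O=C(Nc1cnc(-n2nccn2)c(Cl)c1)Nc1cnc2ccccc2c1C1CC1` gives 1580 nM
compound 3 `COC(C)c1c(NC(=O)Nc2cnc(-n3nccn3)c(Cl)c2)cnc2ccccc12` gives 620 nM

Of these three, compound 3 has the lowest number, 620 nM, and its gaps to the other two lie beyond the scatter, a 2.5-fold lower number from compound 2 to compound 3 (0.41 log units; beyond the scatter) and a 12-fold lower number from compound 1 to compound 3 (1.06 log units; beyond the scatter). The next compound, compound 4 `CCOC(C)c1c(NC(=O)Nc2cnc(-n3nccn3)c(Cl)c2)cnc2ccccc12`, differs from compound 3 in one place, (methyl in place of hydrogen on a saturated chain carbon bound to an oxygen on a saturated carbon). Methoxy becomes ethoxy, so 1-methoxyethyl turns into 1-ethoxyethyl.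

Within the data shown here, no measured step makes this change. The nearest evidence comes from replacing the whole group on an aromatic carbon, which gave a 4.5-fold lower number from compound 1 to compound 2 (0.66 log units; beyond the scatter), as well as the large 12-fold lower number from compound 1 to compound 3 (1.06 log units; beyond the scatter) and the modest 2.5-fold lower number from compound 2 to compound 3 (0.41 log units; beyond the scatter). These steps show that this assay responds to the group at this place, but each exchanges far more than the single methyl added here, and none tests the end of the ether chain. A smaller step is therefore expected, most likely within the scatter, with only a slight lean towards a lower number and no firm direction. The estimated change is a 1.2-fold lower number from compound 3 to compound 4 (0.08 log units; within the scatter). For compound 4 the expected value is 520 nM, with an estimated range from 210 nM to 1300 nM.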

Compound 4, half-maximal effective concentration: 1530 nM
The estimate for compound 4 lay 2.9-fold (0.47 log units) below the measured number; measured number above the stated range.
By their numbers in this assay, from the lowest: compound 3; then compounds 4 and 2 (each within the scatter of the next); then compound 1.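

In this assay the end of the ether chain matters on its own, something the earlier exchanges of the whole group could not show: the single methyl that turns methoxy into ethoxy gives a 2.5-fold higher number from compound 3 to compound 4 (0.39 log units; beyond the scatter) and so undoes much of what 1-methoxyethyl had gained at this place. Set against the other two groups, 1-ethoxyethyl shows a 1.0-fold lower number from compound 2 to compound 4 (0.01 log units; within the scatter) when it replaces cyclopropyl and a 4.7-fold lower number from compound 1 to compound 4 (0.67 log units; beyond the scatter) when it replaces methyl, so an ether chain here does not in itself give a lower number than cyclopropyl, and among these compounds only the 1-methoxyethyl of compound 3 does so. Nothing available explains the effect of the added methyl.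

The compounds shown leave open whether the trend continues along the chain, as a longer group such as 1-propoxyethyl would test, or whether removing the methyl of the methoxy group altogether, to give 1-hydroxyethyl, would lower the number further. They also do not separate the role of the ether oxygen from that of the branching methyl, which a plain methoxymethyl group would address.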